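The source may report more compounds than this note shows. Statements on the series, on what has been measured and on what is new or still open speak of the compounds shown alone.

- compound 1 `CC(=O)c1ccc(OCCCN2CCN(c3ncccn3)CC2)cc1`: > 100 nM
- compound 2 `CCC(=O)c1ccc(OCCCN2CCN(c3ncccn3)CC2)cc1`: > 100 nM

Both entries come from a functional assay on L5178Y cells (Mus musculus) for cytotoxicity, read by MTT assay; on this read-out lower numbers stand for stronger inhibition and higher numbers for weaker inhibition. Compound 2 stands at > 100 nM, which is a limit and not a number. What has been measured so far is the limit of > 100 nM in this assay, at which 2 of the 2 values shown sit.

Compound 3 `CC(C)(C)c1ccc(OCCCN2CCN(c3ncccn3)CC2)cc1` has tert-butyl in place of propanoyl on an aromatic carbon, para to a large group: tert-butyl in place of propanoyl on an aromatic carbon. Among the compounds with values here, the only measured step is a step that the two limits leave unreadable from compound 1 to compound 2, so it offers no size or direction to carry over. No clear change is therefore expected, and another limit is the likeliest result. The estimated step is a step that the limit leaves unreadable from compound 2 to compound 3. For compound 3 the expected value is 150 nM, with an estimated range of 50 nM to 1000 nM.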

Compound 3, half-maximal inhibitory concentration: 40.4 nM
Compound 3: the middle estimate sits 3.7-fold (0.57 log units) above what was measured, outside the stated range (below it).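

In this assay, this aromatic carbon, para to a large group, now gives its first readable change: tert-butyl in place of propanoyl gives an at least 2.4-fold lower number from compound 2 to compound 3 (0.39 log units; beyond the scatter), and tert-butyl in place of acetyl gives an at least 2.4-fold lower number from compound 1 to compound 3 (0.39 log units; beyond the scatter). The step between the two carbonyl-bearing groups could not be read, so the position only now shows that its substituent matters. Both sizes are minimums, since each comparison starts from a limit: the limit of > 100 nM in this assay, at which 2 of the 3 values shown sit.

As far as these compounds go, whether the loss of the carbonyl or the arrival of tert-butyl counts more stays open. So does how an isopropyl group, an amine or a carboxylic acid would fare at this carbon.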